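This account rests on a few compounds, and the source may have more. Where it says the series, first, only, none or still open, it means among the compounds named here.

Working notes on the series in an assay for inhibition of Dihydrofolate reductase (Homo sapiens); on this read-out lower numbers stand for lower potency and higher numbers for higher potency (the scale is a negative logarithm).

Compound 1 `CCOC(=O)CC[C@H](NC(=O)c1ccc(CNc2ccc3nc(N)nc(N)c3c2)cc1)C(=O)OCC` gives 7.54. Compound 2 `CCOC(=O)CC[C@H](NC(=O)c1ccc(CNc2ccc3nc(N)nc(N)c3c2C)cc1)C(=O)OCC` carries the change methyl in place of hydrogen on an aromatic carbon on the core of compound 1; in this assay compound 2 gives 7.7, so that the step is a number 0.16 log units higher from compound 1 to compound 2 (within the scatter). Compound 3 `Nc1nc(N)c2cc(NC(=O)CCc3ccc(Cl)cc3)ccc2n1` rests on a different core, and the difference between the two cores is not broken down here; in this assay compound 3 gives 7.33, a number within the scatter of that of compound 1 and beyond the scatter below that of compound 2.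

Compound 4 `Cc1c(NC(=O)CCc2ccc(Cl)cc2)ccc2nc(N)nc(N)c12` has not yet been measured. It differs from compound 3 by methyl in place of hydrogen on an aromatic carbon, and the surroundings of the place are described in the same words as for the change from compound 1 to compound 2, so the change is taken as the same one, seen twice among these compounds. Within the data shown here, the only guide to what the change does is the one measured pair, where its step was within the scatter; whether it carries over to the core of compound 3 is not known from these data. Among the measured compounds shown here, the step of a number 0.17 log units higher from compound 3 to compound 4 (within the scatter) is expected to be of about the size of a number 0.16 log units higher from compound 1 to compound 2 (within the scatter), with the single measured example as its only support. Compound 4 is therefore estimated at 7.5, between 7.1 and 7.9.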

Compound 4, logarithm of the reciprocal of the active concentration, log(1/C): 7.48
Beside the measured number, compound 4's estimate is 0.02 log units above it; the measured number falls inside the stated range.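

In this assay, the methyl in place of hydrogen on an aromatic carbon gives a second step, a number 0.15 log units higher from compound 3 to compound 4 (within the scatter), and it agrees with the earlier step on the other core: the same change on two cores in this assay, a number 0.16 log units higher (within the scatter) from compound 1 to compound 2 and a number 0.15 log units higher (within the scatter) from compound 3 to compound 4, 0.01 log units apart, within the scatter of two such steps

On these two cores, then, the change can be carried from one to the other with no detectable difference in the size of its step, and the step on one core would have served as a fair guide to the step on the other. This does not show that the methyl itself alters the number, since each step lies within the scatter, and two small steps that agree say little about a change that might have a larger step elsewhere, so the agreement is limited to this pair of cores in this one assay.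

As far as these compounds go, it remains open whether another group on the same aromatic carbon, such as ethyl, methoxy, chlorine or an amine, would give a step beyond the scatter on either core, and whether such a step would also carry over. From the compounds shown here alone, it is equally open whether the methyl step stays the same on a core bearing a free carboxylic acid in place of the two ethyl esters.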